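Neopentyl in place of 2-fluorobenzyl on the imidazole side chain

The source may hold more compounds than are shown below. What is called first, only, known or untested is meant among the compounds shown, and "the series" means these compounds.

Measured so far in an in vitro functional assay on cells for agonist activity at Bombesin receptor subtype-3 (Homo sapiens), read by luminescence and calcium flux; on this read-out lower numbers stand for an effect already at smaller amounts and higher numbers for an effect only at larger amounts of compound:
- compound 1 `O=C(O)c1ccccc1-c1ccc(CCc2ncc(CC3CCCCC3)[nH]2)cc1`: 41 nM
- compound 2 `CCCCc1cnc(C(C)Cc2ccc(-c3ccccc3C(=O)O)cc2)[nH]1`: 2760 nM
- compound 3 `O=C(O)c1ccccc1-c1ccc(CCc2ncc(Cc3ccccc3F)[nH]2)cc1`: 177 nM

Compound 3 stands second of the three numbers in this assay : compound 1 gives the lower number, compound 2 the far higher one. For the measured compounds named here, the only single-place step recorded is a 4.3-fold higher number from compound 1 to compound 3 (0.64 log units; beyond the scatter), a saturated ring giving way to an aromatic one. Compound 4 `CC(C)(C)Cc1cnc(CCc2ccc(-c3ccccc3C(=O)O)cc2)[nH]1` differs from compound 3 by tert-butyl in place of 2-fluorophenyl on a saturated chain carbon bound to an aromatic carbon, so the aromatic ring is removed again and a smaller saturated branch takes its place. Going by the values given here, no measured step covers exactly this change; the reverse of the recorded step argues for a somewhat lower number, while compound 2, which carries a plain butyl chain together with a further change on the linker, gives a much higher number. These pull in opposite directions, so for compound 4 a step of a 1.2-fold lower number from compound 3 to compound 4 (0.07 log units; within the scatter) is expected, not clearly beyond the scatter. Compound 4 is therefore estimated at 150 nM, with a range from 40 nM to 600 nM.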

Compound 4, half-maximal effective concentration: 106 nM
Estimate against measurement, compound 4: 1.4-fold (0.15 log units) above, within the range that was stated.
By their numbers in this assay, from the lowest: compound 1; then compounds 4 and 3 (each within the scatter of the next); then compound 2.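

At this position, an aromatic ring is not required for the effect in this assay: tert-butyl in place of 2-fluorophenyl gives (a 1.7-fold lower number from compound 3 to compound 4 (0.22 log units; within the scatter)), so compound 3 and compound 4 cannot be told apart. The two saturated groups do separate, though only modestly: tert-butyl in place of cyclohexyl gives (a 2.6-fold higher number from compound 1 to compound 4 (0.41 log units; beyond the scatter)), and the cyclohexyl of compound 1 holds the advantage over the smaller branch of compound 4. Nothing at hand explains either step.

Open, from the compounds shown here alone, is whether a smaller ring such as cyclopentyl or a longer chain such as hexyl would match the cyclohexyl of compound 1. Also open, going by these compounds, is how a polar group on this side chain, such as an amine or a hydroxyl, would fare in this assay.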